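From Dimethylphenyl to Chlorophenyl on the Carbonyl Carbon

The source may report more compounds than this note shows. Statements on the series, on what has been measured and on what is new or still open speak of the compounds shown alone.

Compound 1: `COc1ccc(-c2cc(/C=C/C(=O)c3ccc(C)cc3)nc3cc(-c4ccccc4)nn23)cc1OC` — 62600 nM
Compound 2: `COc1ccc(-c2cc(/C=C/C(=O)c3ccc(C)c(C)c3)nc3cc(-c4ccccc4)nn23)cc1OC` — 46200 nM

Both compounds were tested in an ADME assay on HEK293 cells (Homo sapiens) for antiproliferative activity, read by MTT assay, with a stated time of 24 h; on this read-out lower numbers stand for stronger inhibition and higher numbers for weaker inhibition. Compound 1 gives 62600 nM and compound 2 gives 46200 nM. Within the data shown here, the only measured step, a 1.4-fold lower number from compound 1 to compound 2 (0.13 log units; within the scatter), added a methyl to an aromatic carbon. Among the measured compounds shown here, of the two numbers, the one for compound 2 is the smaller, but its gap to compound 1 is within the scatter, so the two compounds cannot be told apart on this read-out. Compound 3, `COc1ccc(-c2cc(/C=C/C(=O)c3ccc(Cl)cc3)nc3cc(-c4ccccc4)nn23)cc1OC`, carries 4-chlorophenyl in place of 3,4-dimethylphenyl on a carbonyl carbon. For the measured compounds named here, no measured step involves a chlorine, so only a 1.4-fold lower number from compound 1 to compound 2 (0.13 log units; within the scatter) bears on this change, and it was within the scatter: altering the aryl group on the carbonyl carbon has so far moved the number little. For compound 3 no step beyond the scatter is expected, a 1.1-fold higher number from compound 2 to compound 3 (0.03 log units; within the scatter). Compound 3 is therefore estimated at 50000 nM, with a range from 20000 nM to 125000 nM.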

Compound 3, half-maximal inhibitory concentration: 44100 nM
The estimate for compound 3 lay 1.1-fold (0.05 log units) above the measured number, within the range that was stated.
By their numbers in this assay, from the lowest: compounds 3, 2 and 1 (each within the scatter of the next).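

In this assay, 4-chlorophenyl in place of 3,4-dimethylphenyl on the carbonyl carbon gives a 1.0-fold lower number from compound 2 to compound 3 (0.02 log units; within the scatter) and chloro in place of methyl on the aromatic carbon gives a 1.4-fold lower number from compound 1 to compound 3 (0.15 log units; within the scatter) and both steps are within the scatter. The earlier pair differed only by one added methyl, whereas this result shows that replacing carbon with chlorine on this aryl group also leaves the number within the scatter. Nothing measured here explains why the three compounds read alike.

Only methyl and chloro substituents on this aryl group are shown, so it remains open whether a methoxy, an amine or a carboxylic acid there would produce a step beyond the scatter. Also open, as far as these compounds go, is what a pyridine ring or a simple butyl chain would do in place of the aryl group on the carbonyl carbon.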